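From an Ether Acid to a Carbon-Linked Acid

The compounds below may be only part of what the source reports. "The series", "measured", "known", "first", "only" and "open" are said of these compounds alone.

Compound 1 `CC(C)Oc1ccc(CNC(=O)c2ccc(C(C)(C)C)cc2)cc1` and compound 2 `CC(C)(C)c1ccc(C(=O)NCc2ccc(OCC(=O)O)cc2)cc1` share one core and differ only in the group on the ring oxygen. In an assay on HeLa cells with Bile acid receptor (Homo sapiens) as the target, read by a luciferase reporter, with a stated time of 24 h (a lower number here means that less compound is needed, a higher number that more compound is needed for the effect), compound 1 gives 170 nM, while compound 2 gives 730 nM. Putting carboxymethyl in place of isopropyl on that oxygen gave a 4.3-fold higher number from compound 1 to compound 2 (0.63 log units; beyond the scatter). Among the compounds with values here, compound 2 therefore stands highest of the two numbers so far, with compound 1 its nearest neighbour.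

Compound 3 `CC(C)(C)c1ccc(C(=O)NCc2ccc(CCC(=O)O)cc2)cc1` differs from compound 2 by 2-carboxyethyl in place of carboxymethoxy on an aromatic carbon. Within the data shown here, no measured step covers this exchange; the single step known, from compound 1 to compound 2, concerns a different change and was of modest size. A carboxylic acid is present in both compound 2 and compound 3, so no step beyond the scatter is expected in this assay, and the estimated step is a 1.0-fold lower number from compound 2 to compound 3 (0.02 log units; within the scatter). Compound 3 is expected to give about 700 nM, within a range from 250 nM to 2000 nM.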

Compound 3, half-maximal effective concentration: 350 nM
Compound 3: the middle estimate sits 2.0-fold (0.30 log units) above what was measured; low and high end bracket the measured number.
By their numbers in this assay, from the lowest: compound 1; then compound 3; then compound 2.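

In this assay, the two acid side chains do not read alike, even though each has the same count of heavy atoms and ends in a carboxylic acid. On an aromatic carbon para to a large group, 2-carboxyethyl in place of carboxymethoxy gave a 2.1-fold lower number from compound 2 to compound 3 (0.32 log units; beyond the scatter) and so the atom linking the chain to the ring counts here, which the earlier pair could not show. Compared with the isopropoxy group, 2-carboxyethyl still gave a 2.1-fold higher number from compound 1 to compound 3 (0.31 log units; beyond the scatter) and so neither acid side chain shown reaches the number of the neutral ether. No measurement shown here explains why the linking atom matters.

The compounds shown leave open how a longer chain ending in the acid, or an amine in place of the acid, would read at this position. They also leave open whether the exchange of carboxymethoxy for 2-carboxyethyl would give a similar step on another core.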